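Replacing the aryl substituent with cyclohexyl on the shared core

This account rests on a few compounds, and the source may have more. Where it says the series, first, only, none or still open, it means among the compounds named here.

In a functional assay on cells for agonist activity at Free fatty acid receptor 1 (Rattus norvegicus), read by FLIPR and calcium flux (a higher number here means that more compound is needed for the effect, a lower number that less compound is needed), compound 1 `CC#C[C@@H](Cc1nnn[nH]1)c1ccc(OCc2ccc3scc(-c4cccnc4C)c3c2)cc1` gives 20 nM. Compound 2 `CC#C[C@@H](Cc1nnn[nH]1)c1ccc(OCc2ccc3scc(-c4cc(OCCOC)ccc4C)c3c2)cc1` gives 26 nM in this assay. Within the data shown here, the only measured step, a 1.3-fold higher number from compound 1 to compound 2 (0.11 log units; within the scatter), exchanged one aromatic substituent for another on the shared core. Among the measured compounds shown here, compound 2 therefore stands at the higher of the two numbers, with compound 1 its only neighbour, and the two are not separated beyond the scatter.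

Compound 3 `CC#C[C@@H](Cc1nnn[nH]1)c1ccc(OCc2ccc3scc(C4CCCCC4)c3c2)cc1` carries the change (cyclohexyl in place of 5-(2-methoxyethoxy)-2-methylphenyl on an aromatic carbon). For the measured compounds named here, no measured step bears directly on this change: the one step available kept an aromatic ring in this place, whereas here a non-aromatic ring enters and the two acceptors of the leaving group are lost. The measured step gives no direction, and the structural change goes further than anything measured, so a wide range is needed.

For compound 3 in this assay the value is estimated at 50 nM, within 12 nM to 220 nM. The estimated step is a 1.9-fold higher number from compound 2 to compound 3 (0.28 log units; within the scatter), leaning towards a higher number but with little weight.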

Compound 3, half-maximal effective concentration: 16 nM
Estimate against measurement, compound 3: 3.1-fold (0.49 log units) above; the range from low to high includes it.
By their numbers in this assay, from the lowest: compounds 3, 1 and 2 (each within the scatter of the next).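

In this assay, the change to cyclohexyl on this aromatic carbon, two ring bonds from the ring sulfur, gives a 1.6-fold lower number from compound 2 to compound 3 (0.21 log units; within the scatter) and, against the pyridine-bearing compound, a 1.3-fold lower number from compound 1 to compound 3 (0.10 log units; within the scatter), so all three numbers remain within the scatter of one another. Where the earlier pair showed only one aromatic ring exchanged for another, compound 3 shows that the six-membered ring at this place need not be aromatic, and that a group of 6 heavy atoms with 0 hydrogen-bond acceptors stands level with one of 12 heavy atoms with 2 hydrogen-bond acceptors. No measurement is available that explains why these numbers lie so close together.

Still open, going by these compounds, is whether this place needs a ring at all, or how a methyl group, a longer alkyl chain, or a cyclohexyl ring carrying an amine or a carboxylic acid would read in this assay. Also open, on these data alone, is whether the same exchanges would stay within the scatter on a core other than the shared core.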